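This account rests on a few compounds, and the source may have more. Where it says the series, first, only, none or still open, it means among the compounds named here.

Measured in an assay on CHO cells for displacement of a labelled ligand from adenosine receptor A3 (Homo sapiens), read by scintillation counting, with a stated time of 45 min, tested at 1 uM, in the presence of a further agent that is not named here; on this read-out higher numbers stand for more inhibition at the one concentration tested (going by the name of the read-out) and lower numbers for less inhibition:

Compound 1, `CCCn1c(=O)[nH]c2nc(-c3ccc(S(=O)(=O)N4CCN(c5cccc(Br)c5)CC4)cc3)[nH]c2c1=O`: 27%
Compound 2, `CCCn1c(=O)[nH]c2nc(-c3ccc(S(=O)(=O)N4CCN(C)CC4)cc3)[nH]c2c1=O`: 7%
Compound 3, `CCCn1c(=O)[nH]c2nc(-c3ccc(S(=O)(=O)N4CCN(c5ccccc5)CC4)cc3)[nH]c2c1=O`: 27%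

All three share the same core and differ only in the group on the amine nitrogen of the six-membered ring with two nitrogens. Compound 1 stands level with compound 3 at the digits shown, and together they give the highest of the three numbers; the only step beyond the scatter is down to compound 2, with a number 20 percentage points lower from compound 1 to compound 2 (beyond the scatter). Going the other way, a number 20 percentage points higher from compound 2 to compound 3 (beyond the scatter), while no change at the digits printed from compound 1 to compound 3 (within the scatter).

Compound 4, `CCCn1c(=O)[nH]c2nc(-c3ccc(S(=O)(=O)N4CCN(c5ccc(F)cc5)CC4)cc3)[nH]c2c1=O`, has not yet been measured. It differs from compound 1 by 4-fluorophenyl in place of 3-bromophenyl on an amine nitrogen in a ring. Among the measured compounds shown here, the step that bears on it most is from compound 1 to compound 3, which removes the bromo and leaves the number unchanged; the steps involving compound 2 show only that taking the aromatic ring away altogether lowers the number modestly. Since compound 4 keeps the aromatic ring on that nitrogen, no change beyond the scatter is expected in this assay.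

Compound 4 is therefore expected to give about 27%, within 12% to 42%. That corresponds to an expected step of no change at the digits printed from compound 1 to compound 4 (within the scatter).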

Compound 4, a percentage reported as inhibition, at one concentration (the size of the read-out at that concentration, not a potency): 38%
Compound 4: middle estimate off by 11 percentage points, on the low side, and the stated range covers the measured number.
By their numbers in this assay, from the lowest: compound 2; then compounds 1 and 3 (each within the scatter of the next); then compound 4.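

In this assay, the group on this ring nitrogen turns out to be more than a plain aromatic ring, since 4-fluorophenyl in place of 3-bromophenyl gives a number 11 percentage points higher from compound 1 to compound 4 (beyond the scatter), and fluoro in place of hydrogen on an aromatic carbon gives a number 11 percentage points higher from compound 3 to compound 4 (beyond the scatter). The earlier pair with and without the bromo showed no such difference, so the new result is the first sign among these compounds that a single atom on the phenyl ring can shift the number beyond the scatter. It also widens the contrast with the small methyl group, with 4-fluorophenyl in place of methyl giving a number 31 percentage points higher from compound 2 to compound 4 (beyond the scatter), although nothing available explains any of these steps.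

From the compounds shown here alone, what 3-fluorophenyl or 4-bromophenyl would give on the same nitrogen remains open, so the identity of the halogen cannot yet be separated from its place on the ring. Also open is how a benzyl group or a 4-methoxyphenyl group would compare there, and a percentage at one concentration gives no potency for any of these compounds.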